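The compounds below may be only part of what the source reports. "The series", "measured", "known", "first", "only" and "open" are said of these compounds alone.

Working notes on the series, read in a functional assay on A-375 cells (Homo sapiens) for antiproliferative activity, read by MTT assay, with a stated time of 24 h; on this read-out higher numbers stand for weaker inhibition and lower numbers for stronger inhibition. Compound 1 `COc1cccc(C(=O)Oc2ccc3c(=O)c(-c4cc(OC)c(OC)cc4OC)coc3c2)c1` gives > 10000 nM, which is a limit of the assay and not a number. Compound 2 `COc1cc(OC)c(-c2coc3cc(OCc4ccccc4C(F)(F)F)ccc3c2=O)cc1OC` gives > 10000 nM, likewise a limit. Among the compounds with values here, compound 2 therefore has no numerical position, and the only other value shown offers no comparison: the limit of > 10000 nM in this assay, at which 2 of the 2 values shown sit. Within the data shown here, the one measured step is a step that the two limits leave unreadable from compound 1 to compound 2, so it provides no size to carry forward.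

Compound 3 `COc1cc(OC)c(-c2coc3cc(OCc4ccccc4C#N)ccc3c2=O)cc1OC` keeps the core of compound 2 and changes one substituent: cyano in place of trifluoromethyl on an aromatic carbon. In words, cyano replaces trifluoromethyl on an aromatic carbon, turning 2-(trifluoromethyl)benzyl into 2-cyanobenzyl. Among the measured compounds shown here, no measured step covers this exchange, so the data support no direction for it, and no change beyond the scatter is expected. The expected step is a step that the limit leaves unreadable from compound 2 to compound 3. The likeliest outcome is that compound 3 also reaches the limit of the assay, though a measurable value cannot be excluded. For compound 3 the estimate is 15000 nM, with an expected range from 4000 nM to 50000 nM.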

Compound 3, half-maximal inhibitory concentration: 990 nM
For compound 3 the middle estimate is 15-fold (1.18 log units) above the measured one; measured number below the stated range.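

In this assay, cyano in place of trifluoromethyl, ortho to a large group, gives an at least 10-fold lower number from compound 2 to compound 3 (1.00 log units; beyond the scatter), so this place on the benzyl group is sensitive to the substituent it carries, which the two earlier compounds could not show. The wider change on the same oxygen, 2-cyanobenzyl in place of (3-methoxyphenyl)carbonyl, gives an at least 10-fold lower number from compound 1 to compound 3 (1.00 log units; beyond the scatter), and compound 2 shows that a 2-substituted benzyl group does not suffice on its own, as the gain appears only with cyano. The step between compound 1 and compound 2 cannot be read, and compound 3 holds the only numerical position in the series, while the other two compounds sit at a limit of the assay and not at a number: the limit of > 10000 nM in this assay, at which 2 of the 3 values shown sit.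

The compounds shown leave open whether an aminomethyl group, a carboxylic acid or a primary amide on the same aromatic carbon would match compound 3 at 990 nM. Also open, going by these compounds, are the full size of the step to cyano and whether cyano would give a measurable value on a benzyl group placed elsewhere on the shared core.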